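Fluoro in Place of Trifluoromethyl at a Second Place

This account rests on a few compounds, and the source may have more. Where it says the series, first, only, none or still open, it means among the compounds named here.

Compound 1 `Cc1ccc(S(=O)(=O)N2C/C(=C\c3cccnc3)C(=O)/C(=C/c3ccccc3F)C2)cc1`, compound 2 `Cc1ccc(S(=O)(=O)N2C/C(=C\c3cccnc3)C(=O)/C(=C/c3ccccc3C(F)(F)F)C2)cc1` and compound 3 `O=C1/C(=C/c2ccncc2)CN(S(=O)(=O)c2ccc(C(F)(F)F)cc2)C/C1=C\c1ccccc1C(F)(F)F` were tested in a functional assay on SMMC-7721 cells (Homo sapiens) for cytotoxicity, read by MTT assay, with a stated time of 24 h; on this read-out higher numbers stand for weaker inhibition and lower numbers for stronger inhibition. In this assay compound 1 gives 10300 nM, compound 2 gives 6700 nM and compound 3 gives 3840 nM. The change fluoro in place of trifluoromethyl on an aromatic carbon brought a 1.5-fold higher number from compound 2 to compound 1 (0.19 log units; within the scatter). The difference between the core of compound 2 and the core of compound 3 is not broken down here. Compound 4 `O=C1/C(=C/c2ccncc2)CN(S(=O)(=O)c2ccc(F)cc2)C/C1=C\c1ccccc1C(F)(F)F` carries fluoro in place of trifluoromethyl on an aromatic carbon, the same kind of change as before, but where the earlier one sat ortho to a large group, this one sits para to a large group. A small step is expected, because a 1.5-fold higher number from compound 2 to compound 1 (0.19 log units; within the scatter) stayed within the scatter, so for compound 4 the expected step is a 1.4-fold higher number from compound 3 to compound 4 (0.13 log units; within the scatter). Compound 4 is therefore estimated at 5200 nM, between 2400 nM and 12000 nM.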

Compound 4, half-maximal inhibitory concentration: 9270 nM
The estimate for compound 4 lay 1.8-fold (0.25 log units) below the measured number; the range from low to high includes it.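

In this assay the exchange of 4-(trifluoromethyl)phenyl for 4-fluorophenyl brought a 2.4-fold higher number from compound 3 to compound 4 (0.38 log units; beyond the scatter) and moved the number in the same direction as the earlier fluoro-for-trifluoromethyl change. Set side by side, the two steps cannot be told apart: the same change on two cores in this assay, a 1.5-fold higher number (0.19 log units; within the scatter) from compound 2 to compound 1 and a 2.4-fold higher number (0.38 log units; beyond the scatter) from compound 3 to compound 4, 1.6-fold (0.20 log units) apart, within the scatter of two such steps. This suggests that the direction and rough size of the change carry from one core to the other, but two pairs establish no rule for the series, and they cannot separate the influence of the core from that of the place of the change, which also differs between the pairs.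

The compounds shown leave open whether the step would hold on further cores. They also leave open how a methoxy group, an amine or a carboxylic acid would compare at the same place.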